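From isopropyl to hexyl on an aromatic oxygen

The source may hold more compounds than are shown below. What is called first, only, known or untested is meant among the compounds shown, and "the series" means these compounds.

Compound 1 `CCCCc1ccc(-c2c(C)[nH]c(=O)n2CCCC)cc1`: 12000 nM
Compound 2 `CCCCOc1ccc(-c2c(C)[nH]c(=O)n2C2CCCCC2)cc1`: 13900 nM
Compound 3 `Cc1[nH]c(=O)n(C)c1-c1ccc(OC(C)C)cc1`: 20400 nM

These numbers come from a functional assay on brain (Rattus norvegicus, strain Wistar) for inhibition; a lower number here means a stronger inhibitor, a higher number a weaker inhibitor. Compound 3, at 20400 nM, lies within the usual scatter of both compound 1 and compound 2, so the three cannot be told apart. Compound 4 `CCCCCCOc1ccc(-c2c(C)[nH]c(=O)n2C)cc1` has hexyl in place of isopropyl on an oxygen on an aromatic ring. Going by the values given here, no measured pair isolates this change. Compound 2 carries butyl on such an oxygen and gives 13900 nM, though it also differs from compound 3 elsewhere. In this assay, a step no larger than the scatter is therefore expected, leaning slightly towards a lower number. For compound 4 the estimated value is 13000 nM, with an expected range of 5000 nM to 30000 nM.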

Compound 4, half-maximal inhibitory concentration: 7300 nM
Estimate against measurement, compound 4: 1.8-fold (0.25 log units) above; low and high end bracket the measured number.
By their numbers in this assay, from the lowest: compounds 4, 1, 2 and 3 (each within the scatter of the next, the first and the last beyond it).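

Hexyl in place of isopropyl on an oxygen on an aromatic ring gives a 2.8-fold lower number from compound 3 to compound 4 (0.45 log units; beyond the scatter) in this assay. This is the only step among these compounds that isolates one change, and it shows that the group on this oxygen can shift the number by more than the usual scatter, although the inhibition remains modest. No available evidence accounts for this step.

As far as these compounds go, whether a longer chain, such as octyl, would lower the number further remains open. So does the effect of a chain ending in an amine or a carboxylic acid.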